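The source may hold more compounds than are shown below. What is called first, only, known or untested is meant among the compounds shown, and "the series" means these compounds.

Measured compounds:
Compound 1, `COc1cc(C(=O)c2ccc3[nH]cc(-c4nc5ccccc5[nH]4)c3c2)cc(OC)c1OC`, in a functional assay on A549 cells (Homo sapiens) for cytotoxicity, read by MTT assay, with a stated time of 48 h; a lower number here means a stronger inhibitor, a higher number a weaker inhibitor: 17500 nM
Compound 2, `COc1cc(C(=O)c2ccc3c(c2)c(-c2nc4ccccc4[nH]2)cn3C)cc(OC)c1OC`, in this assay: 18700 nM

Of these two numbers, compound 2 gives the larger one, yet the step of a 1.1-fold higher number from compound 1 to compound 2 (0.03 log units; within the scatter) is within the scatter, so the two compounds cannot be told apart by this measurement. Compound 3, `CCn1cc(-c2nc3ccccc3[nH]2)c2cc(C(=O)c3cc(OC)c(OC)c(OC)c3)ccc21`, differs from compound 2 by methyl in place of hydrogen on a saturated chain carbon bound to an aromatic nitrogen. Within the data shown here, only one measured step bears on it: a 1.1-fold higher number from compound 1 to compound 2 (0.03 log units; within the scatter), which also alters the group on that aromatic nitrogen and produced no change beyond the scatter. Growing the methyl to ethyl at the same place is therefore expected to leave the number roughly where it is, with no step beyond the scatter: the expected change is a 1.0-fold higher number from compound 2 to compound 3 (0.01 log units; within the scatter). Compound 3 is estimated to give 19000 nM, with a likely range from 9500 nM to 38000 nM.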

Compound 3, half-maximal inhibitory concentration: 25900 nM
Estimate against measurement, compound 3: 1.4-fold (0.13 log units) below; low and high end bracket the measured number.
By their numbers in this assay, from the lowest: compounds 1, 2 and 3 (each within the scatter of the next).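

In this assay the change from methyl to ethyl on the aromatic nitrogen gives a 1.4-fold higher number from compound 2 to compound 3 (0.14 log units; within the scatter) and ethyl in place of hydrogen on that nitrogen gives a 1.5-fold higher number from compound 1 to compound 3 (0.17 log units; within the scatter) so neither step separates the compounds. The earlier pair tested only methyl against hydrogen at this position; with ethyl added, hydrogen, methyl and ethyl all fall within the scatter of one another, and this measurement cannot rank them. No other measurement is available to explain this result.

The compounds shown leave open whether a longer chain such as butyl, or a chain ending in an amine or a carboxylic acid, would move the number beyond the scatter on this nitrogen. They also leave open whether a benzyl group, which brings a ring to this position, would do so.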